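The source may hold more compounds than are shown below. What is called first, only, known or untested is meant among the compounds shown, and "the series" means these compounds.

Measured compounds:
Compound 1 `N#CC1=C(N)Oc2c(c3nc4ccccc4nc3c3ccccc23)C12C(=O)N(Cc1cnnn1-c1ccc(F)cc1)c1ccccc12`: in an ADME assay on L02 cells (Homo sapiens) for antiproliferative activity, read by MTT assay, with a stated time of 48 h (on this read-out higher numbers stand for weaker inhibition and lower numbers for stronger inhibition), compound 1 gives > 50000 nM, a limit of the assay rather than a number.
Compound 2 `N#CC1=C(N)Oc2c(c3nc4ccccc4nc3c3ccccc23)C12C(=O)N(Cc1cnnn1-c1ccccc1Br)c1ccccc12`: in this assay compound 2 gives > 50000 nM, likewise a limit.
Compound 3 `COc1ccc(-n2nncc2CN2C(=O)C3(C(C#N)=C(N)Oc4c3c3nc5ccccc5nc3c3ccccc43)c3ccccc32)cc1`: in this assay compound 3 gives > 50000 nM, again a limit.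

Compound 3 thus stands at the limit of this assay, where every value shown sits (the limit of > 50000 nM in this assay, at which 3 of the 3 values shown sit). Compound 4 `COc1ccccc1-n1nncc1CN1C(=O)C2(C(C#N)=C(N)Oc3c2c2nc4ccccc4nc2c2ccccc32)c2ccccc21` differs from compound 3 in one place: 2-methoxyphenyl in place of 4-methoxyphenyl on an aromatic nitrogen. Three measured steps exist among the compounds shown: a step that the two limits leave unreadable from compound 1 to compound 2, a step that the two limits leave unreadable from compound 1 to compound 3 and a step that the two limits leave unreadable from compound 2 to compound 3. Each of them joins two limits, so none of them carries a readable size, and none shows whether a change of the group on the aromatic nitrogen of the five-membered ring alters the result. For the measured compounds named here, no measured step bears a readable size on the move to the 2-methoxyphenyl group. The expectation for compound 4 therefore rests only on compound 3 standing at the limit together with the other two compounds (the limit of > 50000 nM in this assay, at which 3 of the 3 values shown sit). The expected step of a number no higher from compound 3 to compound 4 (the limit leaves the size open) is none beyond the scatter. Compound 4 is expected to give 50000 nM in this assay, most probably again reported as a limit, with a range from 25000 nM to 100000 nM.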

Compound 4, half-maximal inhibitory concentration: > 50000 nM
Compound 4 was reported as a limit; the forecaster's own chance of this, stated with the estimate: 85%; the middle value lies on the limit itself.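

Compound 4 is also reported as a limit, so its steps from compound 1, compound 2 and compound 3 each join two limits and none can be read: the limit of > 50000 nM in this assay, at which 4 of the 4 values shown sit. The compounds shown leave open whether any of these groups on the aromatic nitrogen changes the result in this assay.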